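Second chloro on the benzamide ring: compound 4

A few compounds are considered here, and "the series" means these few. Any claim that something is new, unique, unknown or untested is made for them only; others in the source may bear on it.

Measured so far in an assay on isolated protein for inhibition of sodium- and chloride-dependent glycine transporter 1 (Homo sapiens); a lower number here means a stronger inhibitor, a higher number a weaker inhibitor:
Compound 1, `O=C(NC[C@]1(CC2CC2)[C@@H]2CN(S(=O)(=O)c3cccnc3)C[C@@H]21)c1ccc(Cl)cc1Cl`, gives 890 nM.
Compound 2, `Cn1cnc(S(=O)(=O)N2C[C@@H]3[C@H](C2)[C@@]3(CNC(=O)c2cccc(C(F)(F)F)c2)CC2CC2)c1`, gives 64 nM.
Compound 3, `Cn1cnc(S(=O)(=O)N2C[C@@H]3[C@H](C2)[C@@]3(CNC(=O)c2ccc(Cl)cc2)CC2CC2)c1`, gives 32 nM.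

Compound 3 has the lowest number of the three in this assay, but the gap to compound 2 is within the scatter, so no order between those two is claimed; only compound 1 stands clearly apart, with a number beyond the scatter above that of compound 3.

Compound 4, `Cn1cnc(S(=O)(=O)N2C[C@@H]3[C@H](C2)[C@@]3(CNC(=O)c2ccc(Cl)cc2Cl)CC2CC2)c1`, keeps the core of compound 3 and differs from it by chloro in place of hydrogen on an aromatic carbon. Among the compounds with values here, the one measured change on the same ring, a 2.0-fold lower number from compound 2 to compound 3 (0.30 log units; within the scatter), was within the scatter. Compound 1 carries the same 2,4-dichlorophenyl as compound 4 but on another core, so its number does not bear directly on this step. Accordingly, no shift beyond the scatter is expected for compound 4 in this assay, that is a 1.3-fold higher number from compound 3 to compound 4 (0.10 log units; within the scatter).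

The expected value of compound 4 in this assay is therefore estimated at 40 nM, within a range of 15 nM to 120 nM.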

Compound 4, half-maximal inhibitory concentration: 4 nM
Compound 4: the middle estimate sits 10-fold (1.00 log units) above what was measured; the measured number lies below the stated range.
By their numbers in this assay, from the lowest: compound 4; then compounds 3 and 2 (each within the scatter of the next); then compound 1.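

Notes on the benzamide ring: in this assay with the core held fixed, chloro in place of hydrogen on an aromatic carbon, ortho to a large group and meta to a chloro group, gives an 8.0-fold lower number from compound 3 to compound 4 (0.90 log units; beyond the scatter) and is thus a step beyond the scatter, unlike a 2.0-fold lower number from compound 2 to compound 3 (0.30 log units; within the scatter) on the same ring. The swap of 3-(trifluoromethyl)phenyl for 2,4-dichlorophenyl gives a 16-fold lower number from compound 2 to compound 4 (1.20 log units; beyond the scatter) on the same core. With 2,4-dichlorophenyl held constant, 1-methyl-1H-imidazol-4-yl in place of pyridin-3-yl on the sulfonyl sulfur gives a 220-fold lower number from compound 1 to compound 4 (2.35 log units; beyond the scatter) and shows that the sulfonyl substituent also carries a large step.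

Open, as far as these compounds go, is whether fluoro, methyl or methoxy on that same aromatic carbon would match chloro. The numbers come with no measurement that accounts for the step.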